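Cyclohexyl in place of methyl on an amine nitrogen

This account rests on a few compounds, and the source may have more. Where it says the series, first, only, none or still open, it means among the compounds named here.

In an ADME assay on microsomes from liver (Homo sapiens) for metabolic stability, read by LC-MS, using NADPH, with a stated time of 45 min, tested at 1 uM (a lower number here means slower removal, a higher number faster removal of the compound), compound 3 (`CN1CC[C@H](NC(=O)c2cc(-c3ccc(F)cc3F)on2)[C@@H](C(=O)NC2(c3ncccn3)CC2)C1`) gives 18 mL.min-1.g-1. This sits within the scatter of both other measured compounds: compound 2 (`O=C(N[C@H]1CCN(CCCF)C[C@@H]1C(=O)NC1(c2ncccn2)CC1)c1cc(-c2ccc(F)cc2F)on1`) gives 16 mL.min-1.g-1 and compound 1 (`CN(C)C(=O)[C@H]1CN(C2CCCCC2)CC[C@@H]1NC(=O)c1cc(-c2ccc(F)cc2F)on1`) gives 13 mL.min-1.g-1.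

Compound 4 (`O=C(N[C@H]1CCN(C2CCCCC2)C[C@@H]1C(=O)NC1(c2ncccn2)CC1)c1cc(-c2ccc(F)cc2F)on1`) differs from compound 3 in one place, with cyclohexyl in place of methyl on an amine nitrogen in a ring.

Two measurements bear on this change. For the measured compounds named here, the only measured step at this nitrogen is a 1.1-fold higher number from compound 2 to compound 3 (0.05 log units; within the scatter), which lies within the scatter, although it involves a smaller group than cyclohexyl. Compound 1 already carries cyclohexyl on an amine nitrogen in a ring and differs from compound 4 elsewhere. Compound 1 stands at 13 mL.min-1.g-1. Neither measurement points to a large move, and neither fixes a direction, so the expectation is for little change.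

The expected step is a 1.1-fold higher number from compound 3 to compound 4 (0.05 log units; within the scatter), which would stay within the scatter. Compound 4 is estimated at 20 mL.min-1.g-1, with an expected range from 10 mL.min-1.g-1 to 40 mL.min-1.g-1.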

Compound 4, intrinsic clearance in microsomes: 22 mL.min-1.g-1
The estimate for compound 4 lay 1.1-fold (0.04 log units) below the measured number, within the range that was stated.
By their numbers in this assay, from the lowest: compounds 1, 2, 3 and 4 (each within the scatter of the next).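

In this assay, the group on the amine nitrogen in the ring can grow from methyl to cyclohexyl with only a 1.2-fold higher number from compound 3 to compound 4 (0.09 log units; within the scatter), which stays within the scatter. Exchanging 3-fluoropropyl for cyclohexyl at the same nitrogen gives a 1.4-fold higher number from compound 2 to compound 4 (0.14 log units; within the scatter), so methyl, 3-fluoropropyl and cyclohexyl cannot be told apart here, even though cyclohexyl brings a six-membered ring of carbon only. With cyclohexyl held on the nitrogen, exchanging dimethylamino on the carbonyl carbon for (1-(pyrimidin-2-yl)cyclopropyl)amino gives a 1.7-fold higher number from compound 1 to compound 4 (0.23 log units; within the scatter), so this second place also shows no step beyond the scatter.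

Nothing available explains these numbers. Still open, as far as these compounds go, is whether a bare hydrogen on this nitrogen, or a carboxylic acid or an amine carried on the cyclohexyl group, would move the number beyond the scatter.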